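Swapping a Pyridine for a Fluorophenyl on the Core

This account rests on a few compounds, and the source may have more. Where it says the series, first, only, none or still open, it means among the compounds named here.

Among the measured compounds shown here, compound 2 `Cc1cc(C(=O)O)ccc1CN1CCC[C@H](O[C@H](CO)c2cc(Cl)cc(Cl)c2)[C@@H]1c1cccnc1` is one of two compounds measured in an assay on isolated protein for activation of cGMP-dependent protein kinase 1 (Homo sapiens), read by ADP-Glo, with stated times of 30 min and 2 h, in the presence of a further agent that is not named here; a higher number here means that more compound is needed for the effect, a lower number that less compound is needed. In this assay compound 2 gives 47000 nM, the highest of the two numbers; its closest neighbour is compound 1 `Cc1cc(C(=O)O)ccc1CN1CCC[C@H](O[C@H](CO)c2cc(Cl)cc(Cl)c2)[C@@H]1c1cccc(F)c1`, which in this assay gives 12000 nM. The two differ in the group on a saturated ring carbon of the shared core: compound 1 carries 3-fluorophenyl, compound 2 pyridin-3-yl. The step of a 3.9-fold higher number from compound 1 to compound 2 (0.59 log units; beyond the scatter) was modest yet beyond the scatter. Compound 3 `Cc1cc(C(=O)O)ccc1CN1CCC[C@H](O[C@H](CO)c2cc(Cl)cc(Cl)c2)[C@@H]1c1ccc(F)cc1` reverses this kind of change, with 4-fluorophenyl in place of pyridin-3-yl on a saturated ring carbon. For the measured compounds named here, the only measured step that bears on it is the one just described, so a step of similar size in the opposite direction, toward a lower number, is expected, while the change from 3-fluorophenyl to 4-fluorophenyl has no measured counterpart here. Compound 3 is therefore estimated at 15000 nM, within 5000 nM to 45000 nM, a change of a 3.1-fold lower number from compound 2 to compound 3 (0.50 log units; beyond the scatter).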

Compound 3, half-maximal effective concentration: 18000 nM
For compound 3 the middle estimate is 1.2-fold (0.08 log units) below the measured one; the measured number falls inside the stated range.
By their numbers in this assay, from the lowest: compounds 1 and 3 (each within the scatter of the next); then compound 2.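

Putting 4-fluorophenyl in place of pyridin-3-yl on this saturated ring carbon gives a 2.6-fold lower number from compound 2 to compound 3 (0.42 log units; beyond the scatter), so a second fluorophenyl group also needs less compound than the pyridine in this assay. Changing 3-fluorophenyl to 4-fluorophenyl gives a 1.5-fold higher number from compound 1 to compound 3 (0.18 log units; within the scatter), so these two groups cannot be told apart here, and among these three compounds, the step away from compound 2 does not depend on which of the two fluorophenyl groups is used. The data offer no measurement that accounts for the gap between the pyridine and the fluorophenyl groups.

On these data alone, what a plain phenyl group, a 4-chlorophenyl group or a saturated cyclohexyl group would give at this position remains open. So does whether pyridin-4-yl would match compound 2 or the two fluorophenyl compounds.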